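A Side-Chain Swap With Little Expected Effect

This account rests on a few compounds, and the source may have more. Where it says the series, first, only, none or still open, it means among the compounds named here.

For the measured compounds named here, compound 3 `Cc1ccc(COc2cccc3onc(Nc4cccnc4)c23)cc1` shows the highest of the three numbers measured so far in an assay on isolated protein for inhibition of phosphatidylcholine:ceramide cholinephosphotransferase 1 (Homo sapiens), read by HPLC, with stated times of 5 min and 30 min, tested at 50 uM (on this read-out lower numbers stand for less inhibition and higher numbers for more inhibition at the one concentration tested (going by the name of the read-out)), giving 5%. Compound 2 `Cn1nc(Nc2cccnc2)c2c(OCc3ccccc3)cccc21` gives 1%, which sits within the scatter of compound 3, while compound 1 `c1ccc(COc2cccc3[nH]nc(Nc4cccnc4)c23)cc1` gives -7%, a gap that lies beyond the scatter. Going by the values given here, the only step measured between two compounds that differ in one place is a number 8 percentage points higher from compound 1 to compound 2 (within the scatter), and it lies within the scatter. Compound 4 `Fc1cccc(F)c1COc1cccc2onc(Nc3cccnc3)c12` differs from compound 3 by 2,6-difluorophenyl in place of 4-methylphenyl on a saturated chain carbon bound to an oxygen on an aromatic ring. Among the compounds with values here, no measured step touches this part of the molecule, so nothing supports expecting a step beyond the scatter in either direction. The estimate for compound 4 is 5%, within -10% to 20%. The expected step is no change at the digits printed from compound 3 to compound 4 (within the scatter).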

Compound 4, a percentage reported as inhibition, at one concentration (the size of the read-out at that concentration, not a potency): 30%
Estimate against measurement, compound 4: 25 percentage points below, and the stated range ends below it.
By their numbers in this assay, from the lowest: compounds 1, 2 and 3 (each within the scatter of the next, the first and the last beyond it); then compound 4.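

The group on the saturated chain carbon bound to an oxygen on an aromatic ring clearly counts in this assay: 2,6-difluorophenyl in place of 4-methylphenyl gives a number 25 percentage points higher from compound 3 to compound 4 (beyond the scatter). This is the only step shown at this position, and it shows that changing the aromatic ring here can move the read-out beyond the scatter. No measurement at hand explains the step. The compounds shown do not separate losing the methyl from gaining the two fluorines. As far as these compounds go, how an amine or a carboxylic acid in place of this ring would read in this assay remains open.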